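Thiosemicarbazone series: aryl replacement on the imine carbon

The source may report more compounds than this note shows. Statements on the series, on what has been measured and on what is new or still open speak of the compounds shown alone.

Among the compounds with values here, compound 2 `CC1=CC[C@H](C(C)(C)NC(=S)N/N=C/c2cccc(Cl)c2)CC1` carries 3-chlorophenyl on the carbon with a double bond to nitrogen, and in a functional assay on PC-3 cells (Homo sapiens) for inhibition, read by sulforhodamine B assay, with a stated time of 48 h (on this read-out higher numbers stand for weaker inhibition of growth and lower numbers for stronger inhibition of growth), compound 2 gives 600 nM, the only number on hand in this assay. Compound 1 `CC1=CC[C@H](C(C)(C)NC(=S)N/N=C/c2ccc(F)cc2)CC1` carries 4-fluorophenyl at the same place. In this assay compound 1 returns < 40 nM, which is a limit of the assay and not a number (the limit of < 40 nM in this assay, at which 1 of the 2 values shown sits). Within the data shown here, the step of an at least 15-fold higher number from compound 1 to compound 2 (1.17 log units; beyond the scatter) is the sole measured step, and it shows that exchanging the aryl group on the imine carbon can move the read-out by a large amount.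

Compound 3 `CC1=CC[C@H](C(C)(C)NC(=S)N/N=C/c2ccc[nH]2)CC1` differs from compound 2 in one place: 1H-pyrrol-2-yl in place of 3-chlorophenyl on a carbon with a double bond to nitrogen. The measured step bears on it only in showing that this position is sensitive; it gives no direction for a change to a five-membered heteroaryl. The expectation is therefore set near compound 2 with a wide range, leaning toward a somewhat lower number, so that compound 3 is estimated at 300 nM, between 60 nM and 1500 nM, a step of a 2.0-fold lower number from compound 2 to compound 3 (0.30 log units; within the scatter) from the value of compound 2.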

Compound 3, concentration for 50% growth inhibition: 2800 nM
The estimate for compound 3 lay 9.3-fold (0.97 log units) below the measured number; the whole stated range lies below it.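

In this assay, the change to 1H-pyrrol-2-yl gives a 4.7-fold higher number from compound 2 to compound 3 (0.67 log units; beyond the scatter), so among the three compounds shown, the five-membered aromatic ring with 1 hetero atom sits behind both halogenated phenyl groups on the carbon with a double bond to nitrogen. The earlier pair showed only that this position is sensitive, whereas this result shows that replacing the phenyl ring here with 1H-pyrrol-2-yl does not preserve the read-out, and the same replacement, set against 4-fluorophenyl, gives an at least 70-fold higher number from compound 1 to compound 3 (1.84 log units; beyond the scatter). The value of compound 1 is a limit of the assay and not a number: the limit of < 40 nM in this assay, at which 1 of the 3 values shown sits.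

The step from 3-chlorophenyl to 1H-pyrrol-2-yl changes ring size, hetero atom and hydrogen-bond donor count together, and the compounds shown do not separate these changes. A 1-methylpyrrol-2-yl group, which keeps the five-membered ring but carries methyl on the ring nitrogen, or a 4-chlorophenyl group, which keeps the chlorine but moves it to the place of the fluorine in compound 1, would each isolate one of the open questions.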